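Compound 2 to compound 4: replacing the sec-butyl group

The source may hold more compounds than are shown below. What is called first, only, known or untested is meant among the compounds shown, and "the series" means these compounds.

Values from an ADME assay on the whole organism (strain Swiss Webster) for metabolic stability, with Mus musculus as the target, using cassette dosing, at a dose of 0.3 mg/kg by the oral route; on this read-out lower numbers stand for a shorter-lived compound and higher numbers for a longer-lived compound
- compound 1 `CCC(C)C(=O)N1CCC(NC(=O)Nc2ccc(C(C)C)cc2)CC1`: 2 h
- compound 2 `CCC(C)C(=O)N1CCC(NC(=O)Nc2ccc(C(F)(C(F)(F)F)C(F)(F)F)cc2)CC1`: 4.5 h
- compound 3 `CCC(C)C(=O)N1CCC(NC(=O)N[C@H]2CC[C@H](CC)CC2)CC1`: 12 h

Of these three, compound 2 has the second highest number, lying above compound 1 and under compound 3. Compound 4 `O=C(Nc1ccc(C(F)(C(F)(F)F)C(F)(F)F)cc1)NC1CCN(C(=O)CC(F)(F)F)CC1` has not yet been measured. It carries 2,2,2-trifluoroethyl in place of sec-butyl on a carbonyl carbon. Among the compounds with values here, no measured step touches that group. The nearest guide is a 2.3-fold higher number from compound 1 to compound 2 (0.35 log units; beyond the scatter), a modest step, in which 1,2,2,2-tetrafluoro-1-(trifluoromethyl)ethyl replaced isopropyl on an aromatic carbon. That step also put a fluorinated group in place of a hydrocarbon one, but elsewhere in the molecule, so it bears only loosely. Within the data shown here, a small rise in this assay is therefore expected, no larger than that step and possibly lost in the scatter. The expected change is a 1.3-fold higher number from compound 2 to compound 4 (0.12 log units; within the scatter). Compound 4 is estimated at 6 h, with an expected range of 2.5 h to 14 h.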

Compound 4, half-life: 18.9 h
Estimate against measurement, compound 4: 3.2-fold (0.50 log units) below, and the stated range ends below it.
By their numbers in this assay, from the lowest: compound 1; then compound 2; then compounds 3 and 4 (each within the scatter of the next).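

In this assay the sec-butyl group on the carbonyl carbon turns out to have a real bearing on the read-out: 2,2,2-trifluoroethyl in its place gives a 4.2-fold higher number from compound 2 to compound 4 (0.62 log units; beyond the scatter) and so lengthens the half-life. Within the data shown here, the only step available before, a 2.3-fold higher number from compound 1 to compound 2 (0.35 log units; beyond the scatter) concerned a group on an aromatic carbon, so this result shows that a second place in the molecule also responds, and that a fluorinated group in place of a hydrocarbon one raised the number in both steps. No measurement shown here explains the rise.

An ethyl group on the same carbonyl carbon would help separate the part played by the fluorine atoms from that of the change in the chain. As far as these compounds go, whether 2,2,2-trifluoroethyl gives a similar step on compound 1 or compound 3 also remains open.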